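The compounds below may be only part of what the source reports. "The series", "measured", "known", "first", "only" and "open" are said of these compounds alone.

Compound 3 `O=c1cc(N2CCN(CC3CCC(O)CC3)CC2)sc2c([N+](=O)[O-])cc(C(F)(F)F)cc12` carries a hydroxy on a saturated ring carbon. In an ADME assay on cells (Hepatocyte, Homo sapiens) for metabolic stability, with a stated time of 30 min (a lower number here means that less of the compound is left, a higher number that more of the compound is left), compound 3 gives 72.7%. Compound 1 `Nc1cc(C(F)(F)F)cc2c(=O)cc(N3CCN(CC4CCC(O)CC4)CC3)sc12` differs from it only by amino in place of nitro on an aromatic carbon, and in this assay compound 1 gives 72.9%; the change a number 0.2 percentage points lower from compound 1 to compound 3 (within the scatter) is within the scatter, so the two sit together. Compound 2 `CS(=O)(=O)NC1CCC(CN2CCN(c3cc(=O)c4cc(C(F)(F)F)cc([N+](=O)[O-])c4s3)CC2)CC1` carries methanesulfonamido where compound 3 carries hydroxy, and in this assay compound 2 gives 105%; the change a number 32.3 percentage points lower from compound 2 to compound 3 (beyond the scatter) is large and beyond the scatter. Compound 3 therefore stands together with compound 1 and well below compound 2.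

Compound 4 `COc1ccc(C(=O)OC2CCC(CN3CCN(c4cc(=O)c5cc(C(F)(F)F)cc([N+](=O)[O-])c5s4)CC3)CC2)cc1` is formed from compound 3 by the change ((4-methoxyphenyl)carbonyl in place of hydrogen on an oxygen on a saturated carbon). Among the compounds with values here, the only measured step at this position is the one from compound 2 to compound 3, which was large, so a change at the oxygen on the saturated carbon can move the number well beyond the scatter. Within the data shown here, no measured step covers the entry of a carbonyl-bearing group there, so the direction is open. Compound 4 is estimated at 50%, within 15% to 85%, which corresponds to an expected step of a number 22.7 percentage points lower from compound 3 to compound 4 (beyond the scatter).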

Compound 4, percent of the compound remaining: 12.2%
Estimate against measurement, compound 4: 37.8 percentage points above; measured number below the stated range.
By their numbers in this assay, from the lowest: compound 4; then compounds 3 and 1 (each within the scatter of the next); then compound 2.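

In this assay, (4-methoxyphenyl)carbonyl in place of hydrogen on an oxygen on a saturated carbon gives a number 60.5 percentage points lower from compound 3 to compound 4 (beyond the scatter) and so shows that a change at this oxygen can take the number far down from the hydroxy compound, a direction the earlier compounds had not shown at this place. Measured against methanesulfonamido on the same saturated ring carbon, ((4-methoxyphenyl)carbonyl)oxy gives a number 92.8 percentage points lower from compound 2 to compound 4 (beyond the scatter) and widens the range seen at this position well beyond what the exchange of methanesulfonamido for hydroxy had revealed, with the three groups now standing apart from one another beyond the scatter. Nothing given here bears on the reason for this fall.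

The compounds shown leave open whether the fall belongs to the carbonyl on the oxygen or to the 4-methoxyphenyl ring, a question that a plain acetyl or a 4-methoxybenzyl ether on the same oxygen would address. They also leave open whether amino in place of nitro on the aromatic carbon, a change that stayed within the scatter with hydroxy present, would stay there with ((4-methoxyphenyl)carbonyl)oxy present.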